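Quinoxaline sulfones: methoxy added to the bromophenyl anilino compound

A few compounds are considered here, and "the series" means these few. Any claim that something is new, unique, unknown or untested is made for them only; others in the source may bear on it.

Measured so far:
compound 1 `COc1ccc(Nc2nc3ccccc3nc2S(=O)(=O)c2ccccc2)cc1` — 1510 nM
compound 2 `O=S(=O)(c1ccc(Br)cc1)c1nc2ccccc2nc1Nc1ccccc1` — 1180 nM

In a functional assay on PC-3 cells (Homo sapiens) for cytotoxicity, read by MTT assay, with a stated time of 72 h (a higher number here means a weaker inhibitor, a lower number a stronger inhibitor), compound 2 gives 1180 nM, the lowest of the two numbers. Compound 1, the nearest, gives 1510 nM; the gap to compound 2 is within the scatter, so the two are treated as equal. For the measured compounds named here, no step between two measured compounds that differ in one place exists here; compound 1 and compound 2 differ in two places.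

Compound 3 `COc1ccc(Nc2nc3ccccc3nc2S(=O)(=O)c2ccc(Br)cc2)cc1` is to be measured in this assay. It differs from compound 2 by methoxy in place of hydrogen on an aromatic carbon, para to a large group. Compound 1 carries the same methoxy group without the bromine and sits within the scatter of compound 2 in this assay, so no step beyond the scatter is expected from compound 2 to compound 3: the expected step is a 1.0-fold higher number from compound 2 to compound 3 (0.01 log units; within the scatter). Compound 3 is estimated at 1200 nM, with a range from 500 nM to 2900 nM.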

Compound 3, half-maximal inhibitory concentration: 1110 nM
Estimate against measurement, compound 3: 1.1-fold (0.03 log units) above, within the range that was stated.
By their numbers in this assay, from the lowest: compounds 3, 2 and 1 (each within the scatter of the next).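

In this assay, methoxy in place of hydrogen on an aromatic carbon, para to a large group, gives a 1.1-fold lower number from compound 2 to compound 3 (0.03 log units; within the scatter), and bromo in place of hydrogen on an aromatic carbon gives a 1.4-fold lower number from compound 1 to compound 3 (0.13 log units; within the scatter). Compound 1 and compound 2 differ in two places, so neither change could be read alone until compound 3 linked them, and each now reads as a single step within the scatter on this core. No measured evidence bears on these results.

As far as these compounds go, whether any group at this position can move the number beyond the scatter remains open, as a single methoxy group says little about an amine, a carboxylic acid or a longer alkoxy chain there. The series also leaves open whether bromo and methoxy would behave the same way in another cell line.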